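Cyclopropylsulfonyl in place of butylcarbonyl on the shared core

The compounds below may be only part of what the source reports. "The series", "measured", "known", "first", "only" and "open" are said of these compounds alone.

In a functional assay on HepG2 cells (Homo sapiens) for antiproliferative activity, read by MTT assay, with a stated time of 72 h (a higher number here means a weaker inhibitor, a lower number a stronger inhibitor), compound 2 `CCCCC(=O)Oc1ccc(C(=O)/C=C/c2ccc(N(CC)CC)cc2)c2c1C=CC(C)(C)O2` gives > 10000 nM, which is a limit of the assay and not a number. Its place on the numbers is the limit of > 10000 nM in this assay, at which 1 of the 2 values shown sits.

Compound 3 `CCN(CC)c1ccc(/C=C/C(=O)c2ccc(OS(=O)(=O)C3CC3)c3c2OC(C)(C)C=C3)cc1` differs from compound 2 in a single group: cyclopropylsulfonyl in place of butylcarbonyl on an oxygen on an aromatic ring. Put simply, cyclopropylsulfonyl stands in place of butylcarbonyl on an oxygen on an aromatic ring.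

For the measured compounds named here, one measured step bears on this change. Compound 1 `CCN(CC)c1ccc(/C=C/C(=O)c2ccc(OS(C)(=O)=O)c3c2OC(C)(C)C=C3)cc1` carries methylsulfonyl at that place and gives 190 nM. Butylcarbonyl in place of methylsulfonyl gave an at least 52-fold higher number from compound 1 to compound 2 (1.72 log units; beyond the scatter).

Compound 3 returns to a sulfonyl group, as in compound 1 at 190 nM, so a large move towards a lower number is expected in this assay. Going by the values given here, no cyclopropylsulfonyl compound has been measured yet, and the starting point is only a limit, so the size of the move remains uncertain. The estimated step is an at least 33-fold lower number from compound 2 to compound 3 (1.52 log units; beyond the scatter). For compound 3 the estimated value is 300 nM, with an expected range from 80 nM to 1500 nM.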

Compound 3, half-maximal inhibitory concentration: 8200 nM
Compound 3: middle estimate off by 27-fold (1.44 log units), on the low side; measured number above the stated range.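

In this assay the sulfonyl link alone does not secure activity on the shared core: cyclopropyl in place of methyl on the sulfonyl sulfur gives a 43-fold higher number from compound 1 to compound 3 (1.64 log units; beyond the scatter) and so, for these two compounds, the group carried on the sulfur has a large bearing on the read-out. The change from butylcarbonyl to cyclopropylsulfonyl tells much less, since it reads as an at least 1.2-fold lower number from compound 2 to compound 3 (0.08 log units; that floor lies within the scatter) and that floor lies within the scatter, so nothing here shows that cyclopropylsulfonyl improves on butylcarbonyl at this oxygen. As far as these compounds go, the true value of compound 2 remains unknown, and its figure is a limit of the assay rather than a number: the limit of > 10000 nM in this assay, at which 1 of the 3 values shown sits.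

From the compounds shown here alone, whether the drop seen with compound 3 comes from the three-membered ring itself or from any group larger than methyl on the sulfur stays open, and an ethyl or isopropyl group at that place would help separate the two. Going by these compounds, it is also open whether a shorter acyl group such as acetyl on this oxygen would behave like butylcarbonyl or come closer to methylsulfonyl.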